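The source may report more compounds than this note shows. Statements on the series, on what has been measured and on what is new or still open speak of the compounds shown alone.

Measured compounds:

Compound 1 `O=c1[nH]cc(S(=O)(=O)Nc2ccccc2-c2cn(-c3cccc(Cl)c3)nn2)c(=O)[nH]1`. In an ADME assay on L02 cells (Homo sapiens) for cytotoxicity, read by MTT assay, with a stated time of 24 h (on this read-out lower numbers stand for higher toxicity in this test and higher numbers for lower toxicity in this test), compound 1 gives only a limit, > 100000 nM.

Compound 2 `O=c1[nH]cc(S(=O)(=O)Nc2ccccc2-c2cn(-c3ccc(Cl)cc3)nn2)c(=O)[nH]1`. In this assay compound 2 gives 16800 nM.

Compound 3 `O=c1[nH]cc(S(=O)(=O)Nc2ccc(-c3cn(-c4cccc(Cl)c4)nn3)cc2)c(=O)[nH]1`. In this assay compound 3 gives 19000 nM.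

Compound 2 arises from compound 1 by 4-chlorophenyl in place of 3-chlorophenyl on an aromatic nitrogen. In this assay this gives an at least 5.9-fold lower number from compound 1 to compound 2 (0.77 log units; beyond the scatter), a step whose size is known only as a lower bound because of the limit of > 100000 nM in this assay, at which 1 of the 3 values shown sits. The difference between the cores of compound 1 and compound 3 is not broken down here. The values of compound 2 and compound 3 in this assay lie within the scatter of each other.

Compound 4 `O=c1[nH]cc(S(=O)(=O)Nc2ccc(-c3cn(-c4ccc(Cl)cc4)nn3)cc2)c(=O)[nH]1` is not yet measured. It arises from compound 3 by 4-chlorophenyl in place of 3-chlorophenyl on an aromatic nitrogen, the same change as that from compound 1 to compound 2. Compound 4 is expected to give about 8000 nM in this assay, with a likely range from 3000 nM to 30000 nM. The expected step of a 2.4-fold lower number from compound 3 to compound 4 (0.38 log units; beyond the scatter) is set smaller than the earlier one because an at least 5.9-fold lower number from compound 1 to compound 2 (0.77 log units; beyond the scatter) rests on the limit of > 100000 nM in this assay, at which 1 of the 3 values shown sits, and is known only as a lower bound. The estimate also takes into account that compound 3 starts from 19000 nM.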

Compound 4, half-maximal cytotoxic concentration: 42900 nM
Estimate against measurement, compound 4: 5.4-fold (0.73 log units) below; the whole stated range lies below it.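

In this assay, 4-chlorophenyl in place of 3-chlorophenyl gives a 2.3-fold higher number from compound 3 to compound 4 (0.35 log units; beyond the scatter), opposite in direction to the step on the core of compound 1, so the change does not carry from one core to the other: the same change on two cores in this assay, an at least 5.9-fold lower number (0.77 log units; beyond the scatter) from compound 1 to compound 2 and a 2.3-fold higher number (0.35 log units; beyond the scatter) from compound 3 to compound 4, at least 13-fold (1.12 log units) apart, beyond the scatter of two such steps. Compound 1 gives only a limit, so the earlier step is known only as a lower bound: the limit of > 100000 nM in this assay, at which 1 of the 4 values shown sits. These two pairs do not show why the steps differ, nor what the change would give on any other core.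

The compounds shown leave open what a plain phenyl, a fluorophenyl or a methoxyphenyl on the same aromatic nitrogen would give on either core. Also open, as far as these compounds go, is how an amine or a carboxylic acid on that ring would read in this assay.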